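Swapping the aryl group on a sulfonyl sulfur: three inactive compounds

The compounds below may be only part of what the source reports. "The series", "measured", "known", "first", "only" and "open" are said of these compounds alone.

Compound 1 `COc1cc(C)ccc1S(=O)(=O)NC1=NCCN1C(=S)SN1CCn2c1nsc2=S`: in a functional assay on KYSE-510 cells (Homo sapiens) for antiproliferative activity, read by crystal violet staining, with a stated time of 96 h (a lower number here means a stronger inhibitor of growth, a higher number a weaker inhibitor of growth), compound 1 gives >= 20000 nM, which is a limit of the assay and not a number.
Compound 2 `O=S(=O)(NC1=NCCN1C(=S)SN1CCn2c1nsc2=S)c1ccc(C(F)(F)F)cc1`: compound 2 gives >= 20000 nM, again a limit.
Compound 3 `O=S(=O)(NC1=NCCN1C(=S)SN1CCn2c1nsc2=S)c1ccc(Cl)cc1Cl`: compound 3 gives >= 20000 nM, also a limit.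

Among the measured compounds shown here, compound 3 therefore stands where every measured compound stands, at the limit of >= 20000 nM in this assay, at which 3 of the 3 values shown sit; no member of the set has yet given a readable number. The three comparisons that differ in one place, a step that the two limits leave unreadable from compound 1 to compound 2, a step that the two limits leave unreadable from compound 1 to compound 3 and a step that the two limits leave unreadable from compound 2 to compound 3, are all of a size that cannot be read, since both ends of each are limits.

Compound 4 `O=S(=O)(NC1=NCCN1C(=S)SN1CCn2c1nsc2=S)c1ccc(F)c(Cl)c1` differs from compound 3 by 3-chloro-4-fluorophenyl in place of 2,4-dichlorophenyl on a sulfonyl sulfur. The measured steps bear on this change only in that each aryl replacement so far has left the value at the limit, so no direction or size of step beyond the scatter can be expected. The step from compound 3 to compound 4 is expected to be a step that the limit leaves unreadable from compound 3 to compound 4. For compound 4 the estimated value is 30000 nM, within a range from 10000 nM to 100000 nM, most likely reported again as a limit.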

Compound 4, concentration for 50% growth inhibition: >= 20000 nM
Compound 4 gave a limit, no number (the forecaster's own chance of this, stated with the estimate: 85%); the middle value does not contradict the limit.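

Compound 4 also ends in a limit, so its steps from compound 1, compound 2 and compound 3 cannot be read, and none of these aryl groups can be ranked against another: the limit of >= 20000 nM in this assay, at which 4 of the 4 values shown sit.

From the compounds shown here alone, whether any aryl group on the sulfonyl sulfur would give a readable number in this assay stays open.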